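The compounds below may be only part of what the source reports. "The series", "measured", "known", "first", "only" and "open" are said of these compounds alone.

Notes on the series. Compound 1 `COc1cc(/C=C/C(=O)Nc2ccccc2)ccc1OCCCCN(C)C` in a physicochemical assay for lipophilicity, using the shake flask method, measured as octanol-water partition, at pH 7.4 (on this read-out lower numbers stand for lower lipophilicity and higher numbers for higher lipophilicity), gives 1.57. Compound 2 `CCN(CC)CCCCOc1ccc(/C=C/C(=O)Nc2ccccc2)cc1OC` in this assay gives 1.59, and compound 3 `COc1cc(/C=C/C(=O)Nc2ccccc2)ccc1OCCCCCCCCN(C)C` in this assay gives 1.74. Compound 4 `CCN(CC)CCCCCCCCOc1ccc(/C=C/C(=O)Nc2ccccc2)cc1OC` has not yet been measured in this assay.

Compound 1 and compound 2 differ by diethylamino in place of dimethylamino on a saturated chain carbon, four bonds along the chain from an oxygen on an aromatic ring, a change that gave a number 0.02 log units higher from compound 1 to compound 2 (within the scatter). Compound 1 and compound 3 differ by 4-(dimethylamino)butyl in place of dimethylamino on a saturated chain carbon, four bonds along the chain from an oxygen on an aromatic ring, which gave a number 0.17 log units higher from compound 1 to compound 3 (within the scatter), and the related pair gave a number 0.15 log units higher from compound 2 to compound 3 (within the scatter). All three numbers sit within the scatter of one another, so no order among compound 1, compound 2 and compound 3 can be read from them.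

Compound 4 stands to compound 3 as compound 2 stands to compound 1: diethylamino in place of dimethylamino on a saturated chain carbon, eight bonds along the chain from an oxygen on an aromatic ring. The cores differ in the way just described for compound 1 and compound 3. The place is not identical, though: in the measured pair the change sits four bonds along the chain from an oxygen on an aromatic ring, in the new pair eight bonds along the chain from an oxygen on an aromatic ring, so this is the same kind of change rather than the same change. Among the compounds with values here, the expectation rests on the single earlier instance, a number 0.02 log units higher from compound 1 to compound 2 (within the scatter), which was within the scatter. For compound 4 the step of a number 0.03 log units higher from compound 3 to compound 4 (within the scatter) is expected to be of similar, small size. Compound 4 is therefore estimated at 1.77, with a range from 1.5 to 2.05, in this assay.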

Compound 4, partition coefficient: 1.75
Compound 4: the middle estimate sits 0.02 log units above what was measured; measured number inside the range.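

In this assay diethylamino in place of dimethylamino on a saturated chain carbon, eight bonds along the chain from an oxygen on an aromatic ring, gave a number 0.01 log units higher from compound 3 to compound 4 (within the scatter) and the same kind of change four bonds along the chain gave a number 0.02 log units higher from compound 1 to compound 2 (within the scatter) so in both cores the step stays within the scatter. The other two new steps, a number 0.16 log units higher from compound 2 to compound 4 (within the scatter) and a number 0.18 log units higher from compound 1 to compound 4 (within the scatter) also stay within the scatter, so no order can be read among the four compounds. This shows that the change carried from the core of compound 1 to the core of compound 3 without a step that can be told from the scatter, but two pairs do not show that it would do so in other cores or at other chain positions, and no measurement at hand bears on why the steps are this small.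

Still open, as far as these compounds go, is whether a larger amine substituent such as dipropylamino, or a longer chain between the oxygen and the amine, would give a step beyond the scatter in this assay series. Also open, from the compounds shown here alone, is how a carboxylic acid in place of the amine would read in this assay on either chain.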